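Cytotoxicity limits and a smaller carbonyl substituent

A few compounds are considered here, and "the series" means these few. Any claim that something is new, unique, unknown or untested is made for them only; others in the source may bear on it.

Compound 1 (`C=C[C@@](C)(/C=C/c1ccc(O)cc1)CC/C=C/C(=O)c1ccccc1`): > 36600 nM (a limit)
Compound 2 (`C=C[C@@](C)(/C=C/c1ccc(O)c(/C=C/C(=O)c2ccccc2)c1)CCC=C(C)C`): > 7410 nM (a limit)

In an ADME assay on HEK293 cells (Homo sapiens) for cytotoxicity, with a stated time of 72 h (a higher number here means that more compound is needed for the effect, a lower number that less compound is needed), compound 2 stands only at a limit, reported as > 7410 nM and not as a number. Compound 3 (`C=C[C@@](C)(/C=C/c1ccc(O)c(/C=C/C(N)=O)c1)CCC=C(C)C`) has amino in place of phenyl on a carbonyl carbon, which turns benzoyl into carbamoyl (amino in place of phenyl on a carbonyl carbon). For the measured compounds named here, neither measured compound gives a number, so the data offer no measured step as a guide. The expected step that the limit leaves unreadable from compound 2 to compound 3 points modestly towards more compound being needed, with wide uncertainty. For compound 3 the estimated value is 25000 nM (expected range 8000 nM to 80000 nM).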

Compound 3, half-maximal effective concentration: > 36600 nM
Compound 3: no number, only a limit (the forecaster's own chance of this, stated with the estimate: 70%); at least 1.4-fold (0.16 log units) between middle value and limit.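

Compound 2 and compound 3 are both reported only as limits in this assay, and the step between them cannot be read. The compounds shown leave open whether amino in place of phenyl on a carbonyl carbon changes the concentration needed for the effect.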